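This account rests on a few compounds, and the source may have more. Where it says the series, first, only, none or still open, it means among the compounds named here.

Compound 1 `O=C1COc2ccc(-c3cccc(NS(=O)(=O)c4ccc(F)cc4)c3)cc2N1c1ccccc1` — in a functional assay on A549 cells (Homo sapiens) for antiproliferative activity, read by MTT assay, with a stated time of 72 h (a lower number here means a stronger inhibitor, a higher number a weaker inhibitor), compound 1 gives > 40000 nM, which is a limit of the assay and not a number; this is the limit noted as the limit of > 40000 nM in this assay, at which 1 of the 3 values shown sits.
Compound 2 `CC(C)N1C(=O)COc2ccc(-c3cccc(NS(=O)(=O)c4ccc(F)cc4)c3)cc21` — in this assay compound 2 gives 29400 nM.
Compound 3 `O=C1COc2ccc(-c3cccc(NS(=O)(=O)c4ccc(F)cc4)c3)cc2N1c1ccc(Cl)cc1` — in this assay compound 3 gives 31600 nM.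

Among the two numbers that are not limits, compound 3 and compound 2 sit within the scatter of each other, as the step of a 1.1-fold higher number from compound 2 to compound 3 (0.03 log units; within the scatter) shows, so neither can be called the stronger or weaker of the pair. Compound 3 is also reached from compound 1 by the step of an at least 1.2-fold lower number from compound 1 to compound 3 (0.10 log units; that floor lies within the scatter), whose floor lies within the scatter as well.

Compound 4 `O=C1COc2ccc(-c3cccc(NS(=O)(=O)c4ccc(F)cc4)c3)cc2N1c1ccc(F)cc1` is not yet measured. It differs from compound 3 in one place: fluoro in place of chloro on an aromatic carbon. Among the measured compounds shown here, the step from compound 1 to compound 3, which also concerns a halogen on this aromatic carbon, gave no change beyond the scatter, and no measured step swaps one halogen for another. The change to compound 4 is therefore expected to give no step beyond the scatter, about a 1.1-fold lower number from compound 3 to compound 4 (0.02 log units; within the scatter), in this assay.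

Compound 4 is estimated to give 30000 nM, within a range from 14000 nM to 65000 nM.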

Compound 4, half-maximal inhibitory concentration: > 40000 nM
Compound 4 ended at the assay's limit; the forecaster's own chance of this, stated with the estimate: 30%; middle value at least 1.3-fold (0.12 log units) away from the limit.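

Among the compounds shown here, compound 4 gives the first direct comparison of fluoro with chloro on this aromatic carbon, para to a large group, and the result is an at least 1.2-fold higher number from compound 3 to compound 4 (0.10 log units; that floor lies within the scatter), so in this assay the swap cannot be called a loss. The comparison with the isopropyl group on the ring nitrogen reads an at least 1.3-fold higher number from compound 2 to compound 4 (0.13 log units; that floor lies within the scatter), so the 4-fluorophenyl group cannot be separated from it either, and the remaining step, between the two limits, cannot be read. The value of compound 4 is a limit and not a number, and it adds a second compound at that limit, so neither halogen on the phenyl ring gives a step beyond the scatter: the limit of > 40000 nM in this assay, at which 2 of the 4 values shown sit.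

The compounds shown leave open whether any other group on this aromatic carbon, such as an amine, a methoxy group or a carboxylic acid, would give a clearly lower number than the halogens do. They also leave open whether a longer chain in place of the isopropyl group, or a different group on the amide-type nitrogen, would move the number beyond the scatter.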